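Octylsulfonamido benzoic acids: a stilbene replaces a chlorophenyl

This account rests on a few compounds, and the source may have more. Where it says the series, first, only, none or still open, it means among the compounds named here.

Measured compounds:
compound 1, `CCCCCCCCS(=O)(=O)Nc1cc(-c2ccccc2Cl)ccc1C(=O)O`, 26900 nM
compound 2, `CCCCCCCCS(=O)(=O)Nc1ccc(-c2cccc(F)c2)cc1C(=O)O`, 37600 nM

Both compounds share an octylsulfonamide and a carboxy group on a common core and were tested in an assay on mitochondria (strain BALB/c) for inhibition of glycerol-3-phosphate acyltransferase 1, mitochondrial (Mus musculus), read by scintillation counting, with a stated time of 10 min; on this read-out higher numbers stand for weaker inhibition and lower numbers for stronger inhibition. Compound 1 gives 26900 nM in this assay, and compound 2 gives 37600 nM. The two numbers lie within the usual scatter of repeated measurements, so compound 1 cannot be set apart from compound 2 on these data; both sit in the weak range of this assay.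

Compound 3, `CCCCCCCCS(=O)(=O)Nc1cc(/C=C/c2ccc(OC)cc2)ccc1C(=O)O`, has not yet been measured. It differs from compound 1 in one place: 2-(4-methoxyphenyl)ethenyl in place of 2-chlorophenyl on an aromatic carbon. For the measured compounds named here, no step between two measured compounds informs this change, since compound 1 and compound 2 differ in more than one place. The expectation for compound 3 therefore rests only on the weak numbers of compound 1 and compound 2, and a step of a 1.3-fold lower number from compound 1 to compound 3 (0.13 log units; within the scatter) is expected, that is, no change beyond the scatter or at most a small move toward lower numbers. Compound 3 is thus estimated at 20000 nM in this assay, with a range from 6000 nM to 60000 nM.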

Compound 3, half-maximal inhibitory concentration: 38700 nM
Compound 3: middle estimate off by 1.9-fold (0.29 log units), on the low side; measured number inside the range.
By their numbers in this assay, from the lowest: compounds 1, 2 and 3 (each within the scatter of the next).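

At the aromatic carbon para to a carboxy group, 2-(4-methoxyphenyl)ethenyl in place of 2-chlorophenyl gives a 1.4-fold higher number from compound 1 to compound 3 (0.16 log units; within the scatter) in this assay and so leaves compound 3 and compound 1 indistinguishable on these data. This position therefore carries either of two quite different groups, one an aromatic ring attached directly and the other an aromatic ring held out by a double bond and bearing a methoxy group with its hydrogen-bond acceptor, and both compounds sit in the same weak range of the assay. Nothing available here bears on why the two groups read alike.

From the compounds shown here alone, what remains open is whether any group at this position can move the number beyond the scatter, for instance an amine, a carboxylic acid or a plain hydroxy group in place of the aromatic substituent. Also open, going by these compounds, is how much of the inhibition depends on the octyl chain of the sulfonamide, which a shorter or a longer chain would test, and whether the double bond matters at all compared with a saturated two-carbon link.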